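A few compounds are considered here, and "the series" means these few. Any claim that something is new, unique, unknown or untested is made for them only; others in the source may bear on it.

Measured so far in a functional assay on the whole organism (artery, strain albino) with Rattus norvegicus as the target, with a stated time of 60 min, at a dose of 10 mg/kg by the oral route; on this read-out higher numbers stand for more inhibition at the one dose given (going by the name of the read-out) and lower numbers for less inhibition:

compound 1 `CC1=C(C(=O)Nc2ccc(Br)cc2)C(c2ccc(Cl)cc2Cl)N=C(SCc2ccccc2)N1` gives 6.7%.
compound 2 `CC1=C(C(=O)Nc2ccc(Br)cc2)C(c2ccc(Cl)cc2Cl)N=C(SCc2ccc(Cl)cc2)N1` gives 11.8%.
compound 3 `CC1=C(C(=O)Nc2ccc([N+](=O)[O-])cc2)C(c2ccc(Br)cc2)N=C(SCc2ccccc2)N1` gives 8.2%.

Compound 4 `CC1=C(C(=O)Nc2ccc([N+](=O)[O-])cc2)C(c2ccc(Br)cc2)N=C(SCc2ccccc2Cl)N1` has not yet been measured in this assay.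

The three measured values all lie within the scatter of one another, so no ordering among compound 1, compound 2 and compound 3 can be read from them. For the measured compounds named here, the only one-place change among the measured compounds runs from compound 1 to compound 2: chloro in place of hydrogen on an aromatic carbon. The step this made in this assay is a number 5.1 percentage points higher from compound 1 to compound 2 (within the scatter).

The change from compound 3 to compound 4 is chloro in place of hydrogen on an aromatic carbon. This is the same kind of change as that from compound 1 to compound 2, but not the same: in compound 2 the chloro sits para to a large group, whereas in compound 4 it sits ortho to a large group. The difference between the core of compound 1 and the core of compound 3 is not broken down here.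

Going by the values given here, the step from compound 3 to compound 4 is expected to be a number 3.8 percentage points higher from compound 3 to compound 4 (within the scatter), because a number 5.1 percentage points higher from compound 1 to compound 2 (within the scatter) was itself a step within the scatter, and nothing among the measured compounds points to a larger effect of a chloro on this benzyl ring. Compound 4 is estimated at 12% in this assay, with a range from 2% to 22%.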

Compound 4, a percentage reported as inhibition, in the whole organism at one dose (the size of the read-out at that dose, not a potency): 6.7%
The estimate for compound 4 lay 5.3 percentage points above the measured number, within the range that was stated.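

In this assay, chloro in place of hydrogen on an aromatic carbon, ortho to a large group, turning benzylsulfanyl into (2-chlorobenzyl)sulfanyl, comes to a number 1.5 percentage points lower from compound 3 to compound 4 (within the scatter). Set beside the earlier case of this change on the other core, the two steps cannot be told apart: the same change on two cores in this assay, a number 5.1 percentage points higher (within the scatter) from compound 1 to compound 2 and a number 1.5 percentage points lower (within the scatter) from compound 3 to compound 4, 6.6 percentage points apart, within the scatter of two such steps. This shows only that no dependence of the change on the core can be seen at this one dose; it does not show that the step carries over unchanged, nor that chloro does anything on either core, with both steps within the scatter and the chloro not at the same place in compound 2 and compound 4.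

The compounds shown leave open whether another group on the benzyl ring, such as an amine, a carboxylic acid or a methoxy group, or a longer chain in place of the benzyl group, would give a step beyond the scatter in this assay. Also open, as far as these compounds go, is whether a real difference between the two cores would appear for this change at a dose other than the one given.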